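The source may hold more compounds than are shown below. What is called first, only, known or untested is meant among the compounds shown, and "the series" means these compounds.

Compound 1, `O=C(O)Cc1sc(NC(=O)c2ccccc2)nc1-c1ccc(Cl)cc1`: 870 nM
Compound 2, `O=C(O)Cc1sc(C(c2ccccc2)c2ccccn2)nc1-c1ccc(Cl)cc1`: 1900 nM
Compound 3, `O=C(O)Cc1sc(C(c2ccc(F)cc2)c2ccc(F)cc2)nc1-c1ccccc1`: 240 nM

Of the compounds shown here, three sharing one core have been tested in an in vitro functional assay on HEK285-7 cells for antagonist activity at prostaglandin D2 receptor 2 (Homo sapiens), read by BRET and beta-arrestin recruitment; a lower number here means a stronger inhibitor, a higher number a weaker inhibitor. Compound 3 gives the lowest number of the three, so it is the strongest inhibitor among them. Compound 1 comes nearest, yet its gap to compound 3 is beyond the usual scatter of repeated measurements, and compound 2 lies further still, also beyond the scatter.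

The next compound, compound 4, `CN(C)c1cc(-c2nc(C(c3ccc(F)cc3)c3ccc(F)cc3)sc2CC(=O)O)ccn1`, is not yet measured. It differs from compound 3 in one place on the shared core: 2-(dimethylamino)pyridin-4-yl in place of phenyl on an aromatic carbon. The plain phenyl gives way to a six-membered aromatic ring with one hetero atom that carries a dimethylamino group; the carboxymethyl group and the rest of the core stay the same.

Among the measured compounds shown here, no measured pair shows this kind of swap, so the direction of its effect is open. The step of a 1.3-fold higher number from compound 3 to compound 4 (0.12 log units; within the scatter) is expected to be small, perhaps within the scatter, with a slight lean toward a weaker inhibitor. On that basis compound 4 is expected to give 320 nM, within a range from 80 nM to 1300 nM.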

Compound 4, half-maximal inhibitory concentration: > 100000 nM
Compound 4: no number, only a limit (the forecaster's own chance of this, stated with the estimate: 3%); at least 310-fold (2.49 log units) between middle value and limit.
By their numbers in this assay, from the lowest: compound 3; then compound 1; then compound 2. At a limit, above all of these: compound 4.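

In this assay, putting 2-(dimethylamino)pyridin-4-yl in place of phenyl on this aromatic carbon, the one next to the ring nitrogen and next to the ring atom that bears a carboxymethyl group, gives an at least 410-fold higher number from compound 3 to compound 4 (2.61 log units; beyond the scatter). Going by these compounds, the reading for compound 4 is a limit of the assay and not a number, so the full size of the loss stays unknown: the limit of > 100000 nM in this assay, at which 1 of the 4 values shown sits. The earlier compounds shown here offered no step at this position, and this single change now shows that the group here can decide whether the compounds on the shared core register as inhibitors in this assay at all.

The ring nitrogen and the dimethylamino group enter together, and the compounds shown do not tell whether one of them alone or only the two combined goes with the loss. A plain pyridin-4-yl at this position, or a phenyl carrying a dimethylamino group, would pull the two apart, and a smaller substituent such as a methoxy group on the pyridine ring would test how much of the added group can be kept.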